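The source may hold more compounds than are shown below. What is called first, only, known or untested is meant among the compounds shown, and "the series" means these compounds.

Working notes on the series.

Three compounds share one core, and all three have been measured in a functional assay on a cell-free system (Platelet, plasma, Homo sapiens) for inhibition; a lower number here means a stronger inhibitor, a higher number a weaker inhibitor. Compound 1 `O=C(O)CN1Cc2ccc(NC(=O)CCCC3CCNCC3)cc2C1=O` gives 66000 nM. Compound 2 `O=C(O)CN1Cc2ccc(NC(=O)c3ccc(C4CCNCC4)cc3)cc2C1=O` gives 24000 nM. Compound 3 `O=C(O)CCN1Cc2ccc(NC(=O)c3ccc(C4CCNCC4)cc3)cc2C1=O` gives 9600 nM, the lowest of the three numbers; its nearest neighbour is compound 2 and its furthest is compound 1, both steps being beyond the scatter. Among the measured compounds shown here, the single one-place step among the measured compounds is a 2.5-fold lower number from compound 2 to compound 3 (0.40 log units; beyond the scatter), and it concerns the acid-bearing chain on the core, not the ring at the far end of the amide.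

Compound 4 `O=C(O)CCN1Cc2ccc(NC(=O)c3ccc(N4CCNCC4)cc3)cc2C1=O` is the next compound to be measured. It differs from compound 3 in one place: piperazin-1-yl in place of piperidin-4-yl on an aromatic carbon. For the measured compounds named here, no measured step in this assay touches that position; compound 1 and compound 2 share the piperidin-4-yl group of compound 3, so the data give no direct guidance on the exchange for piperazin-1-yl. With nothing to anchor a move in either direction, the expectation for compound 4 is a step of about a 1.1-fold lower number from compound 3 to compound 4 (0.03 log units; within the scatter), that is, no change beyond the scatter. The estimate for compound 4 in this assay is therefore 9000 nM, within a range from 3000 nM to 30000 nM.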

Compound 4, half-maximal inhibitory concentration: 540 nM
Compound 4: middle estimate off by 17-fold (1.22 log units), on the high side, and the stated range ends above it.
By their numbers in this assay, from the lowest: compound 4; then compound 3; then compound 2; then compound 1.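

Among the compounds shown here, the position on the aromatic carbon para to a large group, which no earlier step touched, proves highly sensitive in this assay: an 18-fold lower number from compound 3 to compound 4 (1.25 log units; beyond the scatter) is larger than the change at the acid-bearing chain, a 2.5-fold lower number from compound 2 to compound 3 (0.40 log units; beyond the scatter). The exchange keeps the six-membered non-aromatic ring, the 6 heavy atoms, the 1 hydrogen-bond donor and the absence of net charge, while piperazin-1-yl brings 2 nitrogen atoms and 2 hydrogen-bond acceptors where piperidin-4-yl has 1 of each, so a change this small in the counted features is enough to produce a large step in this series. No measurement at hand accounts for the size of this step.

The compounds shown leave open whether the second ring nitrogen itself is required, a question that morpholin-4-yl, with an oxygen in that place, or a methyl group on the free ring nitrogen would test. They also leave open whether the step carries over to the carboxymethyl chain of compound 2 or to a longer acid-bearing chain on the shared core.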